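The compounds below may be only part of what the source reports. "The series", "measured", "known", "first", "only" and "open" are said of these compounds alone.

Series notes. Compound 1 `COc1cc(-c2cc(/C=C/C(=O)c3ccccc3)nc3cc(-c4ccccc4)nn23)cc(OC)c1OC` and compound 2 `COc1ccc(-c2cc(/C=C/C(=O)c3ccccc3)nc3cc(-c4ccccc4)nn23)cc1` share the core and differ only in the aryl group. In an ADME assay on HEK293 cells (Homo sapiens) for antiproliferative activity, read by MTT assay, with a stated time of 24 h (on this read-out lower numbers stand for stronger inhibition and higher numbers for weaker inhibition), compound 1 reaches only a limit of the assay, >= 100000 nM. In this assay, among the compounds with values here, compound 2 gives 53200 nM, the only plain number so far. The step of an at least 1.8-fold lower number from compound 1 to compound 2 (0.27 log units; that floor lies within the scatter) rests on a limit of >= 100000 nM in this assay, at which 1 of the 2 values shown sits, and on one number. Compound 3 `COc1ccc(-c2cc(/C=C/C(=O)c3ccccc3)nc3cc(-c4ccccc4)nn23)cc1OC` adds methoxy in place of hydrogen on an aromatic carbon to compound 2. Compound 3 sits between the two in substitution, and a small step toward compound 1 is expected, a 1.3-fold higher number from compound 2 to compound 3 (0.12 log units; within the scatter). Compound 3 is estimated at 70000 nM, between 35000 nM and 140000 nM.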

Compound 3, half-maximal inhibitory concentration: 51200 nM
Compound 3: middle estimate off by 1.4-fold (0.14 log units), on the high side, within the range that was stated.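

Methoxy in place of hydrogen, ortho to a methoxy group, gives no difference that can be separated from the scatter in this assay, with a 1.0-fold lower number from compound 2 to compound 3 (0.02 log units; within the scatter). So 3,4-dimethoxyphenyl and 4-methoxyphenyl read alike here. Toward the 3,4,5-trimethoxyphenyl group, the comparison gives an at least 1.9-fold lower number from compound 1 to compound 3 (0.29 log units; that floor lies within the scatter), and that step rests on a limit: the limit of >= 100000 nM in this assay, at which 1 of the 3 values shown sits.

Going by these compounds, how far compound 1 truly lies from the other two stays open, and with it whether the further methoxy matters at all. Also open, on these data alone, is how an amine or a carboxylic acid at this position would read.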